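Branching the butyl group of compound 2

The source may report more compounds than this note shows. Statements on the series, on what has been measured and on what is new or still open speak of the compounds shown alone.

In a functional assay on M21 cells (Homo sapiens) for antiproliferative activity, read by sulforhodamine B assay, with a stated time of 48 h (on this read-out higher numbers stand for weaker inhibition and lower numbers for stronger inhibition), compound 1 `CCc1ccccc1NS(=O)(=O)c1ccc(N2CCNC2=O)cc1` gives 180 nM and compound 3 `Cc1ccc(NS(=O)(=O)c2ccc(N3CCNC3=O)cc2)cc1C` gives 94 nM. Compound 2 `CCCCc1ccc(NS(=O)(=O)c2ccc(N3CCNC3=O)cc2)cc1` gives 450 nM, the highest of the three numbers and beyond the scatter from each of the other two. Compound 4 `CC(C)(C)c1ccc(NS(=O)(=O)c2ccc(N3CCNC3=O)cc2)cc1` has not yet been measured and differs from compound 2 in one place: tert-butyl in place of butyl on an aromatic carbon. This puts tert-butyl in place of butyl on an aromatic carbon, with the same atoms joined differently. Among the compounds with values here, the only measured step, a 1.9-fold lower number from compound 1 to compound 3 (0.28 log units; within the scatter), lies within the scatter and involves a different change, 3,4-dimethylphenyl in place of 2-ethylphenyl on a sulfonamide nitrogen, so it bears on this change only weakly. Within the data shown here, no measured step tests butyl against tert-butyl. No step beyond the scatter is therefore expected in this assay, and no direction is favoured, which leaves compound 2 at 450 nM as the anchor. The estimated step is a 1.1-fold lower number from compound 2 to compound 4 (0.05 log units; within the scatter). Compound 4 is expected at 400 nM, with an estimated range of 130 nM to 1200 nM.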

Compound 4, half-maximal inhibitory concentration: > 1000 nM
Compound 4: no number, only a limit; the forecaster's own chance of this, stated with the estimate: 3%; middle value at least 2.5-fold (0.39 log units) from the limit.
By their numbers in this assay, from the lowest: compounds 3 and 1 (each within the scatter of the next); then compound 2. At a limit, above all of these: compound 4.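

Compound 4 has no number in this assay, only a limit: the limit of > 1000 nM in this assay, at which 1 of the 4 values shown sits.

With the same atoms joined differently, tert-butyl in place of butyl on an aromatic carbon, para to a large group, gives an at least 2.2-fold higher number from compound 2 to compound 4 (0.34 log units; beyond the scatter), so at this position the way the chain is joined counts, not only its number of heavy atoms. The earlier step, a 1.9-fold lower number from compound 1 to compound 3 (0.28 log units; within the scatter), stayed within the scatter and could not show this.

As far as these compounds go, the true size of the step stays open, as only its lower end is fixed by the limit. Also open, from the compounds shown here alone, is whether an isobutyl or isopropyl group at this place behaves like butyl or like tert-butyl, and whether an amine or a carboxylic acid there is tolerated.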